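The compounds below may be only part of what the source reports. "The series", "measured", "known", "first", "only" and "open" are said of these compounds alone.

In a functional assay on A549 cells (Homo sapiens) for inhibition, read by MTT assay, with a stated time of 72 h (a lower number here means a stronger inhibitor, a higher number a weaker inhibitor), compound 1 `COc1ccccc1-n1c(-c2coc3cc(C)c(Cl)cc3c2=O)nc(-c2ccccc2)c1-c1ccccc1` gives 12500 nM. Compound 2 `Cc1cc2occ(-c3nc(-c4ccccc4)c(-c4ccccc4)n3-c3ccc(Cl)cc3)c(=O)c2cc1Cl` gives 12500 nM, and compound 3 `Cc1cc2occ(-c3nc(-c4ccccc4)c(-c4ccccc4)n3-c3ccccc3Cl)c(=O)c2cc1Cl` gives 12500 nM, so compound 1 stands level with both. Compound 4 `Cc1cc2occ(-c3nc(-c4ccccc4)c(-c4ccccc4)n3-c3cccc([N+](=O)[O-])c3)c(=O)c2cc1Cl` keeps the core of compound 1 and carries 3-nitrophenyl in place of 2-methoxyphenyl on an aromatic nitrogen. The measured steps that bear on this change are no change at the digits printed from compound 1 to compound 2 (within the scatter), no change at the digits printed from compound 1 to compound 3 (within the scatter) and no change at the digits printed from compound 2 to compound 3 (within the scatter). All three alter the aryl group on that nitrogen, and none goes beyond the scatter. For the measured compounds named here, no measured compound carries 3-nitrophenyl, so this reading is an extrapolation. The step expected in this assay is no change at the digits printed from compound 1 to compound 4 (within the scatter), none beyond the scatter. For compound 4 the estimated value is 12500 nM, with an expected range of 6000 nM to 25000 nM.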

Compound 4, half-maximal inhibitory concentration: 6250 nM
Estimate against measurement, compound 4: 2.0-fold (0.30 log units) above, within the range that was stated.
By their numbers in this assay, from the lowest: compounds 4, 1, 2 and 3 (each within the scatter of the next).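

In this assay, a nitro-bearing aryl group on the aromatic nitrogen stays within the scatter of each earlier compound: (a 2.0-fold lower number from compound 1 to compound 4 (0.30 log units; within the scatter)), (a 2.0-fold lower number from compound 2 to compound 4 (0.30 log units; within the scatter)) and (a 2.0-fold lower number from compound 3 to compound 4 (0.30 log units; within the scatter)). The flat reading at this position now covers 3-nitrophenyl as well as 2-methoxyphenyl, 4-chlorophenyl and 2-chlorophenyl. No evidence on a cause bears on these steps.

As far as these compounds go, whether an aminophenyl or carboxyphenyl group, or a longer chain in place of the aryl ring on this nitrogen, would read the same remains open. So does whether any change to the shared core would move the number.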